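This account rests on a few compounds, and the source may have more. Where it says the series, first, only, none or still open, it means among the compounds named here.

Measured compounds:
compound 1, `COc1cc(C)cc(-c2c(-c3ccnc(-c4ccc(C(C)=O)cc4)c3)cnn2CC#N)c1`, 95%
compound 2, `COc1cc(C)cc(-c2nn(CC#N)cc2-c2ccc(-c3cccc(C(C)=O)c3)nc2)c1`, 99%
compound 3, `COc1cc(C)cc(-c2nn(CC#N)cc2-c2ccnc(-c3ccc(N(C)C)cc3)c2)c1`, 25%

Compound 1 stands second highest of the three numbers in a functional assay on HT-29 cells (Homo sapiens) for cytotoxicity, read by sulforhodamine B assay, with a stated time of 48 h, tested at 100 nM; on this read-out lower numbers stand for a stronger effect and higher numbers for a weaker effect at the one concentration tested. Its nearest neighbour is compound 2, whose value lies four points higher and within the scatter, so no order between the two can be claimed. Its furthest neighbour is compound 3, whose value lies lower by a margin well beyond the scatter.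

Compound 4, `COc1cc(C)cc(-c2c(-c3ccnc(-c4ccc(N(C)C)cc4)c3)cnn2CC#N)c1`, has not yet been measured in this assay. It differs from compound 1 in one place: dimethylamino in place of acetyl on an aromatic carbon. The same difference, cut one bond further out, reads 4-acetylphenyl to 4-(dimethylamino)phenyl.

Going by the values given here, no step between measured compounds is given. Still, the 4-(dimethylamino)phenyl group that enters in compound 4 is the group carried by compound 3, which gives 25% in this assay, a far stronger effect than compound 1. The step of a number 60 percentage points lower from compound 1 to compound 4 (beyond the scatter) is therefore expected to be large and toward a stronger effect, beyond the scatter. Compound 4 is expected to give 35%, with a range from 10% to 70%.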

Compound 4, a percentage reported as activity, at one concentration (the size of the read-out at that concentration, not a potency): -24%
The estimate for compound 4 lay 59 percentage points above the measured number; measured number below the stated range.
By their numbers in this assay, from the lowest: compound 4; then compound 3; then compounds 1 and 2 (each within the scatter of the next).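

Dimethylamino in place of acetyl is the only change here that can be read at a single place, and in this assay it brings a number 119 percentage points lower from compound 1 to compound 4 (beyond the scatter) as a large step. This position, on an aromatic carbon para to a large group, is therefore far from indifferent: the two groups match in heavy atoms and hydrogen-bond acceptors and carry no net charge, yet compound 4 gives -24% as a reading under zero. No measurement at hand accounts for the size of this step.

The compounds shown leave open whether a primary amine, a methoxy group or a morpholine at this place would read like dimethylamino or like acetyl. Also open, from the compounds shown here alone, is how an unsubstituted phenyl would stand against both groups.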